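This account rests on a few compounds, and the source may have more. Where it says the series, first, only, none or still open, it means among the compounds named here.

Measured so far:
compound 1, `CCc1cccc(NC(=O)CN2CCC(c3cccc[n+]3[O-])CC2)c1`, giving 62% in a functional assay on HEK293 cells for agonist activity at D(4) dopamine receptor (Homo sapiens), read by FLIPR; on this read-out higher numbers stand for larger maximal responses and lower numbers for smaller maximal responses
compound 2, `Cc1cccc(C(=O)NCN2CCC(c3nccs3)CC2)c1`, giving 71%
compound 3, `C=Cc1cccc(C(=O)NCN2CCC(c3cccc[n+]3[O-])CC2)c1`, giving 63%

Compound 1 holds the lowest of these three numbers, yet the nearest of the others, that of compound 3, lies within the scatter of it, and so does the furthest, that of compound 2. Compound 4, `Cc1cc(F)ccc1NC(=O)CN1CCC(c2cccc[n+]2[O-])CC1`, differs from compound 1 in one place: 4-fluoro-2-methylphenyl in place of 3-ethylphenyl on an amide-type nitrogen. Among the compounds with values here, no step between two measured compounds bears on this change, so the measured set gives no direction. Compound 4 is therefore expected to reach about the same maximal response, a step of a number 1 percentage points higher from compound 1 to compound 4 (within the scatter) that is not expected to go beyond the scatter. The estimate for compound 4 in this assay is 63%, with a range from 50% to 78%.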

Compound 4, largest response reached (reported as efficacy), in percent of the reference or control that the assay uses: 84%
Compound 4: middle estimate off by 21 percentage points, on the low side, and the stated range ends below it.
By their numbers in this assay, from the lowest: compounds 1, 3 and 2 (each within the scatter of the next); then compound 4.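

On the amide-type nitrogen the aryl group matters in this assay: 4-fluoro-2-methylphenyl in place of 3-ethylphenyl gives a number 22 percentage points higher from compound 1 to compound 4 (beyond the scatter) and lifts compound 4 beyond the scatter of the other compounds. The two groups match in heavy atoms, in ring type and in hydrogen-bond counts, so these counts do not separate them. Nothing at hand accounts for the step.

Open, from the compounds shown here alone, is whether the fluorine or the methyl carries the step, and whether a methoxy group or an amine on that ring would keep it.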